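The compounds below may be only part of what the source reports. "The series", "measured", "known", "first", "only" and "open" are said of these compounds alone.

Working notes on the series. In an ADME assay on HEp-2 cells (Homo sapiens) for cytotoxicity (a higher number here means that more compound is tolerated, a lower number that less compound is tolerated), compound 1 `CC(C)CCn1c(Cn2c(=O)n(CC(=O)OC(C)(C)C)c3ccccc32)nc2cc(C(=N)N)ccc21` gives 7900 nM and compound 2 `CC(C)CCn1c(Cn2c(=O)n(CC(=O)OC(C)(C)C)c3ccccc32)nc2cc(/C(N)=N\O)ccc21` gives 19800 nM as its value. Compound 3 `C=C(C)n1c(=O)n(Cc2nc3cc(C#N)ccc3n2CCC(C)C)c2ccccc21` stands lowest of the three at 1480 nM in this assay as measured so far.

Compound 4 `CC(C)CCn1c(Cn2c(=O)n(CC(=O)OC(C)(C)C)c3ccccc32)nc2cc(C#N)ccc21` departs from compound 3 at one place: (tert-butoxycarbonyl)methyl in place of 1-methylethenyl on an aromatic nitrogen with (tert-butoxycarbonyl)methyl in place of 1-methylethenyl on an aromatic nitrogen.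

Among the compounds with values here, no measured step isolates this exchange. Within the data shown here, the only step available is a 2.5-fold higher number from compound 1 to compound 2 (0.40 log units; beyond the scatter) and it lies on an aromatic carbon, so it does not bear directly on the change at the nitrogen. Among the measured compounds shown here, it shows only that a modest step occurs among compounds carrying the entering group. The indirect evidence is that compound 1 at 7900 nM and compound 2 at 19800 nM both carry (tert-butoxycarbonyl)methyl and both stand above compound 3, yet they also differ from compound 3 on that aromatic carbon. Part of the gap may therefore belong to that other difference.

A rise is expected, most likely short of the full gap to compound 1. On this evidence a 3.4-fold higher number from compound 3 to compound 4 (0.53 log units; beyond the scatter) is the expected step in this assay for now. For compound 4 the estimate is 5000 nM with an expected range from 1800 nM to 15000 nM in this read-out.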

Compound 4, half-maximal cytotoxic concentration: 32200 nM
For compound 4 the middle estimate is 6.4-fold (0.81 log units) below the measured one, outside the stated range (above it).
By their numbers in this assay, from the lowest: compound 3; then compound 1; then compounds 2 and 4 (each within the scatter of the next).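

In this assay, a 22-fold higher number from compound 3 to compound 4 (1.34 log units; beyond the scatter) isolates the exchange of 1-methylethenyl for (tert-butoxycarbonyl)methyl on the aromatic nitrogen, with the nitrile on the aromatic carbon common to both, so this gap cannot be assigned to any difference at that carbon. With (tert-butoxycarbonyl)methyl held on the nitrogen, a 4.1-fold higher number from compound 1 to compound 4 (0.61 log units; beyond the scatter) is beyond the scatter, whereas a 1.6-fold higher number from compound 2 to compound 4 (0.21 log units; within the scatter) is within it, and both of these steps at the aromatic carbon are smaller than the step at the nitrogen. No measurement in hand accounts for the size of the step at the nitrogen.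

The exchange at the nitrogen alters the group as a whole, so a carboxylic acid in place of the tert-butyl ester, or a plain ethyl chain on the same nitrogen, would be needed to show which part of (tert-butoxycarbonyl)methyl goes with the higher number. Going by these compounds, it also remains open whether a step of this size recurs when 1-methylethenyl is paired with the groups of compound 1 or compound 2 on the aromatic carbon.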